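A chloro group on the compound 3 scaffold

This account rests on a few compounds, and the source may have more. Where it says the series, first, only, none or still open, it means among the compounds named here.

Measured in a functional assay on HCT-116 cells (Homo sapiens) for antiproliferative activity, read by MTT assay, with a stated time of 48 h; a higher number here means a weaker inhibitor, a lower number a stronger inhibitor:
Compound 1 `CCCCCC(CCO)n1cnc2c(Cl)nc(Cl)nc21` gives 6170 nM
Compound 2 `CCCCCCC(CCO)n1cnc2c(Cl)nc(F)nc21` gives 9960 nM
Compound 3 `CCCCCCC(CCO)n1cnc2c(Cl)ncnc21` gives 11900 nM

In this assay the three compounds cannot be told apart, since the value of compound 3 (11900 nM) lies within the usual scatter of the values of both compound 2 and compound 1. Compound 4 `CCCCCCC(CCO)n1cnc2c(Cl)nc(Cl)nc21` has not yet been measured. It departs from compound 3 by one change, (chloro in place of hydrogen on an aromatic carbon), which is chloro in place of hydrogen on an aromatic carbon, between two ring nitrogen atoms.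

The closest measured step concerns the same place on the ring, where hydrogen takes the place of fluoro (a 1.2-fold higher number from compound 2 to compound 3 (0.08 log units; within the scatter)). That exchange stayed within the scatter. Compound 1 already carries chloro at this place, though on a different chain, and its value (6170 nM) also lies within the scatter of compound 3. Neither observation points to a large effect, so no step beyond the scatter is expected in this assay, though a small move toward a lower number is possible.

The expected step is a 1.5-fold lower number from compound 3 to compound 4 (0.17 log units; within the scatter) and it is estimated to stay within the scatter. For compound 4 the estimated value is 8000 nM with an expected range from 4000 nM to 15000 nM in this assay.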

Compound 4, half-maximal inhibitory concentration: 12100 nM
Compound 4: middle estimate off by 1.5-fold (0.18 log units), on the low side; measured number inside the range.
By their numbers in this assay, from the lowest: compounds 1, 2, 3 and 4 (each within the scatter of the next).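

In this assay, chloro in place of hydrogen on the aromatic carbon between two ring nitrogen atoms gives a 1.0-fold higher number from compound 3 to compound 4 (0.01 log units; within the scatter) and stays within the scatter, while chloro in place of fluoro at the same place gives a 1.2-fold higher number from compound 2 to compound 4 (0.08 log units; within the scatter) and also stays within it. Hydrogen, fluoro and chloro at this place therefore cannot be told apart on this chain, a comparison that the earlier compounds could make only for hydrogen and fluoro. With chloro held at this place, methyl in place of hydrogen on a saturated chain carbon, six bonds along the chain from an aromatic nitrogen, gives a 2.0-fold higher number from compound 1 to compound 4 (0.29 log units; within the scatter) and likewise stays within the scatter, so this chain change also leaves the two compounds indistinguishable. No measurement is available that would explain these results.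

The compounds shown leave open whether an amine or a methoxy group at this place would move the number beyond the scatter. They also leave open whether a much shorter chain would do so on the shared core.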